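This account rests on a few compounds, and the source may have more. Where it says the series, first, only, none or still open, it means among the compounds named here.

In a functional assay on HCT-116 cells (Homo sapiens) for cytotoxicity, read by scintillation counting and thymidine incorporation, with a stated time of 72 h (a higher number here means a weaker inhibitor, a lower number a stronger inhibitor), compound 1 `CCOc1cc(C(=CC#N)c2ccc(NC)cc2)ccc1OC`, which carries a cyano group, gives 55 nM. Compound 3 `CCOc1cc(C(=CC#N)c2ccc(S(C)(=O)=O)cc2)ccc1OC` carries the same group but gives > 10000 nM, which is a limit and not a number. Compound 2 `C#CC=C(c1cc(OC)cc(OC)c1)c1ccc(OC)c(OC)c1` gives > 10000 nM, also a limit. Compound 2 thus stands at the limit of > 10000 nM in this assay, at which 2 of the 3 values shown sit, and how far it lies from the other compounds cannot be read from the numbers.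

Compound 4 `COc1cc(OC)cc(C(=CC#N)c2ccc(OC)c(OC)c2)c1` differs from compound 2 in one place: cyano in place of ethynyl on a double-bonded chain carbon bound to a double-bonded chain carbon, with cyano in place of ethynyl on a double-bonded chain carbon bound to a double-bonded chain carbon.

Among the compounds with values here, the only measured step is an at least 180-fold higher number from compound 1 to compound 3 (2.25 log units; beyond the scatter), with methylsulfonyl in place of methylamino on an aromatic carbon. It is large and beyond the scatter, but it lies elsewhere in the structure and bears only indirectly on this change. It does show that cyano alone does not secure a low number, since compound 3 keeps that group and still reaches the limit.

A moderate move towards a lower number in this assay is therefore expected, and a result that stays at the limit would be no surprise. The expected change is an at least 3.3-fold lower number from compound 2 to compound 4 (0.52 log units; beyond the scatter). For compound 4 the estimated value is 3000 nM, with an expected range from 300 nM to 10000 nM.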

Compound 4, half-maximal inhibitory concentration: 18 nM
Estimate against measurement, compound 4: 170-fold (2.22 log units) above; measured number below the stated range.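

In this assay, the exchange of ethynyl for cyano on a double-bonded chain carbon bound to a double-bonded chain carbon gives an at least 550-fold lower number from compound 2 to compound 4 (2.74 log units; beyond the scatter), which shows that this place is far from indifferent to which group it carries, something the earlier step, made elsewhere in the structure, could not show. The two groups match in heavy-atom count and each has one triple bond outside aromatic rings, so what the counts separate is a nitrogen in place of a carbon and one hydrogen-bond acceptor where ethynyl has none, though these compounds alone cannot say whether either of these accounts for the step. The value of compound 2 is a limit and not a number, so the step has a lower bound but no known full size: the limit of > 10000 nM in this assay, at which 2 of the 4 values shown sit.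

What the compounds shown leave open is how groups other than these two behave at this place, such as a carboxylic acid, a primary amide or a longer chain ending in an amine. They also leave open whether the same exchange would have a comparable effect in compounds carrying methylamino or methylsulfonyl, as compound 1 and compound 3 do.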